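Chloro on the benzoyl ring of a fluoro- and methoxyindole pair

The source may hold more compounds than are shown below. What is called first, only, known or untested is meant among the compounds shown, and "the series" means these compounds.

Measured compounds in an ADME assay on HEK293 cells (Homo sapiens) for cytotoxicity, read by MTT assay, with a stated time of 72 h; on this read-out lower numbers stand for stronger inhibition and higher numbers for weaker inhibition:
Compound 1 `O=C(CN1CCN(C(=O)c2ccccc2)CC1)N1CCN(CCCc2c[nH]c3ccc(F)cc23)CC1`, compound 1 gives 148000 nM.
Compound 2 `O=C(CN1CCN(C(=O)c2cccc(Cl)c2)CC1)N1CCN(CCCc2c[nH]c3ccc(F)cc23)CC1`, compound 2 gives 66200 nM.
Compound 3 `COc1ccc2[nH]cc(CCCN3CCN(C(=O)CN4CCN(C(=O)c5ccccc5)CC4)CC3)c2c1`, for compound 3 the assay reports only a limit, > 200000 nM.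

The three compounds share a core and differ in two places. Compound 2 differs from compound 1 by chloro in place of hydrogen on an aromatic carbon, and this change gave a 2.2-fold lower number from compound 1 to compound 2 (0.35 log units; beyond the scatter). Compound 3 differs from compound 1 by methoxy in place of fluoro on an aromatic carbon, and the two cores so differ by that change alone. The step here is an at least 1.3-fold higher number from compound 1 to compound 3 (0.13 log units; that floor lies within the scatter), and it rests on a limit: the limit of > 200000 nM in this assay, at which 1 of the 3 values shown sits.

Compound 4 `COc1ccc2[nH]cc(CCCN3CCN(C(=O)CN4CCN(C(=O)c5ccc(Cl)cc5)CC4)CC3)c2c1` has not yet been measured in this assay. It differs from compound 3 by chloro in place of hydrogen on an aromatic carbon. This is the same kind of change as from compound 1 to compound 2, but not the same: in compound 2 the chloro enters meta to a large group, in compound 4 it enters para to a large group.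

Since compound 3 shows only a limit, the step to compound 4 cannot be placed on a known number. Resting on the earlier step of a 2.2-fold lower number from compound 1 to compound 2 (0.35 log units; beyond the scatter), compound 4 is expected to move by about an at least 1.3-fold lower number from compound 3 to compound 4 (0.12 log units; that floor lies within the scatter) from the limit of compound 3. Compound 4 is therefore estimated at 150000 nM, with a wide range from 60000 nM to 300000 nM, and a fair chance that the assay again returns only a limit.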

Compound 4, half-maximal inhibitory concentration: 117000 nM
For compound 4 the middle estimate is 1.3-fold (0.11 log units) above the measured one, and the stated range covers the measured number.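

In this assay, chloro in place of hydrogen on the benzoyl ring goes with a lower number on the second core as it does on the first, and the new step reads an at least 1.7-fold lower number from compound 3 to compound 4 (0.23 log units; that floor lies within the scatter), so its known floor alone does not carry it beyond the usual scatter. Set beside the earlier step, it points the same way, but this pair of compounds cannot show that the change carries over with the same size: the same change on two cores in this assay, a 2.2-fold lower number (0.35 log units; beyond the scatter) from compound 1 to compound 2 and an at least 1.7-fold lower number (0.23 log units; that floor lies within the scatter) from compound 3 to compound 4; the limit leaves it open whether they differ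

Compound 3 has only a limit, and the chloro also sits in a different place in the two pairs, para to a large group in compound 4 but not in compound 2, so any gap between the steps could not be assigned to the core alone: the limit of > 200000 nM in this assay, at which 1 of the 4 values shown sits.

The compounds shown leave open whether chloro at one and the same place on the ring would give matching steps on the two cores. They also leave open whether a bromo group or a nitrile on the benzoyl ring, or a longer chain on the shared core, would follow the same direction in this cytotoxicity read-out.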